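The compounds below may be only part of what the source reports. "The series", "measured", "known", "first", "only" and "open" are said of these compounds alone.

Measured compounds:
Compound 1 `C#CCOc1ccc(N2CCN(C(=O)ON3C(=O)C4CN(C(=O)c5ccc(Oc6ccccc6)cc5)CCN4C3=O)CC2)cc1`, which in an assay on membranes from brain for binding affinity to Lysophosphatidylserine lipase ABHD12 (Mus musculus), read by fluorescence, with a stated time of 45 min (on this read-out lower numbers stand for stronger inhibition and higher numbers for weaker inhibition), gives 400 nM.
Compound 2 `COc1ccc(N2CCN(C(=O)ON3C(=O)C4CN(Cc5ccc(Oc6ccccc6)cc5)CCN4C3=O)CC2)cc1`, for which this assay reports > 10000 nM, a limit of the assay rather than a number (the limit of > 10000 nM in this assay, at which 1 of the 2 values shown sits).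

Going by the values given here, compound 1 holds the only numerical value here, and compound 2 gives only a limit. Compound 3 `COc1ccc(N2CCN(C(=O)ON3C(=O)C4CN(C(=O)c5ccc(Oc6ccccc6)cc5)CCN4C3=O)CC2)cc1` is not yet measured; it differs from compound 1 by hydrogen in place of ethynyl on a saturated chain carbon bound to an oxygen on an aromatic ring. Among the compounds with values here, no single-change step between measured compounds is available to calibrate this propargyl-to-methyl change, so a moderate loss beyond the scatter is expected, giving a 3.8-fold higher number from compound 1 to compound 3 (0.57 log units; beyond the scatter). Compound 3 is therefore estimated at 1500 nM, with a range of 500 nM to 5000 nM.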

Compound 3, half-maximal inhibitory concentration: 320 nM
The estimate for compound 3 lay 4.7-fold (0.67 log units) above the measured number, and the stated range ends above it.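

In this assay, going by these compounds alone, the change from propargyloxy to methoxy gives a 1.3-fold lower number from compound 1 to compound 3 (0.10 log units; within the scatter), the first reading of this position. The ethynyl group can therefore be removed from this saturated chain carbon without a change beyond the scatter, so it is not required for inhibition at this level. Nothing shown here gives a cause for this result.

Going by these compounds, whether an amine, a carboxylic acid or a longer chain in place of the propargyl would also leave the inhibition unchanged remains open. So does whether the same holds for the enzyme from other species.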